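Removing the Chloro Group From Compound 2

This account rests on a few compounds, and the source may have more. Where it says the series, first, only, none or still open, it means among the compounds named here.

- Compound 1 `COc1cc(-c2nccn3cc(-c4ccc(F)cc4)nc23)cc(OC)c1OC` gives 137 nM
- Compound 2 `COc1cc(-c2nccn3cc(-c4ccc(Cl)cc4)nc23)cc(OC)c1OC` gives 7290 nM
- Compound 3 `COc1cc(-c2nccn3cc(-c4ccc5[nH]ccc5c4)nc23)cc(OC)c1OC` gives 154 nM
- Compound 4 `COc1cc(-c2nccn3cc(-c4ccccc4)nc23)cc(OC)c1OC` is not yet measured

In a functional assay on A549 cells (Homo sapiens) for inhibition, read by MTT assay, with a stated time of 48 h (on this read-out lower numbers stand for stronger inhibition and higher numbers for weaker inhibition), compound 2 shows the highest number of the three and is the weakest. Compound 4 carries hydrogen in place of chloro on an aromatic carbon. The nearest evidence is the chloro-for-fluoro swap, a 53-fold higher number from compound 1 to compound 2 (1.73 log units; beyond the scatter). The move to 1H-indol-5-yl, a 47-fold lower number from compound 2 to compound 3 (1.68 log units; beyond the scatter), is just as large, while a 1.1-fold higher number from compound 1 to compound 3 (0.05 log units; within the scatter) shows two quite different groups matching. Chloro thus looks like the outlier here, though the data hold no direct hydrogen comparison. A large drop is expected, an estimated 15-fold lower number from compound 2 to compound 4 (1.16 log units; beyond the scatter). Compound 4 is expected at about 500 nM, with an estimated range of 120 nM to 3000 nM.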

Compound 4, half-maximal inhibitory concentration: 378 nM
Compound 4: the middle estimate sits 1.3-fold (0.12 log units) above what was measured; low and high end bracket the measured number.
By their numbers in this assay, from the lowest: compounds 1 and 3 (each within the scatter of the next); then compound 4; then compound 2.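

In this assay, the direct comparison with hydrogen gives (a 19-fold lower number from compound 2 to compound 4 (1.29 log units; beyond the scatter)), so the poor result at this position belongs to chloro specifically. Hydrogen does not, however, reach fluoro (a 2.8-fold higher number from compound 1 to compound 4 (0.44 log units; beyond the scatter)) or 1H-indol-5-yl (a 2.5-fold higher number from compound 3 to compound 4 (0.39 log units; beyond the scatter)), so replacing these groups with hydrogen also has a measurable cost. Nothing given here explains these differences.

On these data alone, whether bromo, a nitrile or an amine on this aromatic carbon would fall nearer fluoro or chloro remains open. With only two halogens shown, no trend across that family can be drawn.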